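A Pyroglutamide P2X7 Inhibitor: Benzyl in Place of Furan

A few compounds are considered here, and "the series" means these few. Any claim that something is new, unique, unknown or untested is made for them only; others in the source may bear on it.

Of the compounds shown here, three sharing one core have been measured in an assay on HEK293 cells for inhibition of P2X purinoceptor 7 (Homo sapiens), read by flow cytometry, with stated times of 15 min and 1 h; a higher number here means a weaker inhibitor, a lower number a stronger inhibitor. Compound 1 `O=C(NCc1ccc(Cl)cc1Cl)[C@@H]1CCC(=O)N1c1ccco1` gives 244 nM, the second highest of the three numbers. Compound 2 `O=C(NCc1ccc(Cl)cc1Cl)[C@@H]1CCC(=O)N1c1nccs1` gives 415 nM; the step of a 1.7-fold higher number from compound 1 to compound 2 (0.23 log units; within the scatter) exchanges one five-membered aromatic ring for another on the ring nitrogen of the core. Compound 3 `O=C(NCc1cccc(C(F)(F)F)c1Cl)[C@@H]1CCC(=O)N1c1cccs1` gives 100 nM, but it differs from compound 1 in two places at once, so its value cannot be tied to any single change.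

Compound 4 `O=C(NCc1ccc(Cl)cc1Cl)[C@@H]1CCC(=O)N1Cc1ccccc1Cl` is not yet measured. Compared with compound 1, the change is 2-chlorobenzyl in place of furan-2-yl on an amide-type nitrogen in a ring. For the measured compounds named here, only the step from compound 1 to compound 2 concerns the same position, and it stayed within the scatter; it swapped an aromatic ring for an aromatic ring, whereas compound 4 introduces a 2-chlorobenzyl group of a different kind. Going by the values given here, no measured step shows how this assay responds to such a group there. The expectation is therefore that compound 4 lands near compound 1, with wide uncertainty in either direction, estimated as a 1.4-fold higher number from compound 1 to compound 4 (0.16 log units; within the scatter). In this assay compound 4 is estimated at 350 nM, within a range from 90 nM to 1500 nM.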

Compound 4, half-maximal inhibitory concentration: 3460 nM
Beside the measured number, compound 4's estimate is 9.9-fold (1.00 log units) below it; the whole stated range lies below it.
By their numbers in this assay, from the lowest: compound 3; then compounds 1 and 2 (each within the scatter of the next); then compound 4.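

In this assay, the substituent on the amide-type nitrogen turns out to matter a great deal: putting 2-chlorobenzyl in place of furan-2-yl gives a 14-fold higher number from compound 1 to compound 4 (1.15 log units; beyond the scatter), and putting it in place of 1,3-thiazol-2-yl gives an 8.3-fold higher number from compound 2 to compound 4 (0.92 log units; beyond the scatter). For the compounds shown here, the only earlier step at this position, a 1.7-fold higher number from compound 1 to compound 2 (0.23 log units; within the scatter), stayed within the scatter, so a swap between the two five-membered aromatic rings gave no sign that this position could weaken inhibition so strongly. The new step changes several things at once, with a six-membered aromatic ring of carbon only replacing a five-membered ring with a hetero atom and a chlorine entering as well, and no measurement here explains the loss of inhibition.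

These compounds leave open whether the chlorine, the six-membered ring or the extra carbon of the benzyl group accounts for the change, which a plain benzyl or a phenyl group on the same nitrogen could help to separate. Also open, as far as these compounds go, is how 2-chlorobenzyl would behave alongside the trifluoromethyl-bearing amide part of compound 3.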